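Adding Fluoro to the Benzoyl Ring: Expected Potency

This account rests on a few compounds, and the source may have more. Where it says the series, first, only, none or still open, it means among the compounds named here.

Compound 3 `COc1cc2ncnc(NNC(=S)NC(=O)c3ccccc3)c2cc1OC` gives 3050 nM in a functional assay on MGC-803 cells (Homo sapiens) for cytotoxicity, read by MTT assay, with a stated time of 72 h (on this read-out higher numbers stand for weaker inhibition and lower numbers for stronger inhibition), the lowest of the three numbers, though compound 1 `Cc1ccc(C(=O)NC(=S)NNc2ncnc3ccccc23)cc1` with 3760 nM and compound 2 `O=C(NC(=S)NNc1ncnc2ccccc12)c1cccc(Cl)c1` with 4540 nM both lie within the usual scatter of it, so no real order can be claimed. Compound 4 `COc1cc2ncnc(NNC(=S)NC(=O)c3ccccc3F)c2cc1OC` differs from compound 3 by fluoro in place of hydrogen on an aromatic carbon. Within the data shown here, the only measured step that touches the benzoyl ring, a 1.2-fold higher number from compound 1 to compound 2 (0.08 log units; within the scatter), exchanged one ring group for another and stayed within the scatter, so a fluoro entering that ring is expected to move the number little. The step from compound 3 to compound 4 is therefore expected to be a 1.0-fold lower number from compound 3 to compound 4 (0.01 log units; within the scatter). Compound 4 is expected to give about 3000 nM, between 1500 nM and 6000 nM.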

Compound 4, half-maximal inhibitory concentration: 2390 nM
Compound 4: middle estimate off by 1.3-fold (0.10 log units), on the high side; measured number inside the range.
By their numbers in this assay, from the lowest: compounds 4, 3, 1 and 2 (each within the scatter of the next).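

Putting fluoro on an aromatic carbon, ortho to a large group, gives a 1.3-fold lower number from compound 3 to compound 4 (0.11 log units; within the scatter). This is the first step shown that starts from a bare phenyl ring and keeps the core of compound 3, and it shows that this carbon can carry a fluorine atom with a number that cannot be told apart from that of compound 3. No other measurement here bears on this result.

On these data alone, what an amine or a carboxylic acid on this same carbon would give remains open. So does whether fluoro would give a similar number on the core of compound 1.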